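A few compounds are considered here, and "the series" means these few. Any claim that something is new, unique, unknown or untested is made for them only; others in the source may bear on it.

Measured so far:
Compound 1, `CCC(C(=O)N1CCN(c2ccc(C(F)(F)F)cc2)CC1)N1C(=O)CCC1=O`: 25%
Compound 2, `CC(C(=O)N1CCN(c2ccccc2C(F)(F)F)CC1)N1C(=O)CCC1=O`: 100%
Compound 3, `CCC(C(=O)N1CCN(c2ccccc2C(F)(F)F)CC1)N1C(=O)CCC1=O`: 25%

All three numbers come from a functional assay on the whole organism (strain Swiss) with Mus musculus as the target, in the maximal electroshock model, with a stated time of 0.25 h, at a dose of 300 mg/kg by the intraperitoneal route; a lower number here means a weaker effect, a higher number a stronger effect of the compound at the dose given. Compound 3 stands level with compound 1 at the digits reported, and together the two give the lowest numbers of the set; the distance to compound 2 is large, with compound 2 higher by a margin well beyond the usual scatter. Among the measured compounds shown here, the only step between measured compounds that differ in a single place is a number 75 percentage points lower from compound 2 to compound 3 (beyond the scatter), a methyl in place of hydrogen on a saturated chain carbon.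

Compound 4, `CCC(C(=O)N1CCN(c2ccccc2)CC1)N1C(=O)CCC1=O`, has not yet been measured. It differs from compound 3 by hydrogen in place of trifluoromethyl on an aromatic carbon. For the measured compounds named here, no measured step concerns a change of this kind: the single measured step deals with the chain carbon, not the aromatic ring. Compounds 1 and 3 both carry a trifluoromethyl on the ring, at different places, and show the same number, but neither is without it, so the data give no direction for its removal. The change is therefore expected to stay within the scatter, as an expected step of no change at the digits printed from compound 3 to compound 4 (within the scatter). Compound 4 is estimated at 25%, with a range from 0% to 65%.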

Compound 4, a percentage reported as activity, at one dose (the size of the read-out at that dose, not a potency): 75%
Beside the measured number, compound 4's estimate is 50 percentage points below it, and the stated range ends below it.
By their numbers in this assay, from the lowest: compounds 1 and 3 (each within the scatter of the next); then compound 4; then compound 2.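

In this assay, putting hydrogen in place of the trifluoromethyl on the aromatic ring gives a number 50 percentage points higher from compound 3 to compound 4 (beyond the scatter), and the same exchange starting from the compound that carries this group elsewhere on the ring gives a number 50 percentage points higher from compound 1 to compound 4 (beyond the scatter). The earlier compounds shown here showed only a change on the saturated chain, and the two ring placements they offered stood level, so the ring could have seemed unimportant; these steps show that the ring substituent also has a large effect on the read-out at this dose. Among compound 1, compound 3 and compound 4, which share the same chain, the lower number goes with the presence of trifluoromethyl at either place, but nothing given here explains why removing it gives a higher number.

Going by these compounds, it remains open whether the same exchange would also change the result on the chain of compound 2, which gives 100% while carrying trifluoromethyl. Also open, on these data alone, is how a ring bearing a different group, such as a methyl, a methoxy or a chlorine atom, would compare with compound 4.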